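An Aryl Group Replaces Cyclopropylmethyl in Compound 1

The compounds below may be only part of what the source reports. "The series", "measured", "known", "first", "only" and "open" are said of these compounds alone.

Within the data shown here, compound 1 `CN1C(=O)C(CC2CC2)N(C)c2nc(Nc3ccc(S(N)(=O)=O)cc3)ncc21` bears a cyclopropylmethyl group on a saturated ring carbon of the shared core and gives 211 nM in an assay on Sf9 cells for inhibition of serine/threonine-protein kinase 4 (Homo sapiens), read by luminescence and ADP-Glo, with a stated time of 1 h, in the presence of a further agent that is not named here (a higher number here means a weaker inhibitor, a lower number a stronger inhibitor), the lowest of the three numbers measured so far. Compound 2 `CN1C(=O)C(c2cccc(Cl)c2)N(C)c2nc(Nc3ccc(S(N)(=O)=O)cc3)ncc21` carries a 3-chlorophenyl on the same saturated ring carbon and gives 989 nM; compound 3 `CN1C(=O)C(c2cccc(C(F)(F)F)c2)N(C)c2nc(Nc3ccc(S(N)(=O)=O)cc3)ncc21`, with a 3-(trifluoromethyl)phenyl there, gives 2710 nM. Both aryl replacements raised the number: a 4.7-fold higher number from compound 1 to compound 2 (0.67 log units; beyond the scatter) and a 13-fold higher number from compound 1 to compound 3 (1.11 log units; beyond the scatter), while a 2.7-fold higher number from compound 2 to compound 3 (0.44 log units; beyond the scatter).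

Compound 4 `CN1C(=O)C(c2ccccc2Cl)N(C)c2nc(Nc3ccc(S(N)(=O)=O)cc3)ncc21` is not yet measured. It differs from compound 1 as follows: 2-chlorophenyl in place of cyclopropylmethyl on a saturated ring carbon. The steps from compound 1 to compound 2 and from compound 1 to compound 3 bear most directly on this change, since each also puts an aryl group in place of the cyclopropylmethyl, and the chloro-bearing aryl of compound 2 gave the smaller rise because a 4.7-fold higher number from compound 1 to compound 2 (0.67 log units; beyond the scatter). Compound 4 is therefore expected to show a modest step in the same direction, a 4.7-fold higher number from compound 1 to compound 4 (0.68 log units; beyond the scatter). In this assay compound 4 is estimated at 1000 nM, within a range from 300 nM to 3500 nM.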

Compound 4, half-maximal inhibitory concentration: 129 nM
The estimate for compound 4 lay 7.8-fold (0.89 log units) above the measured number, outside the stated range (below it).
By their numbers in this assay, from the lowest: compounds 4 and 1 (each within the scatter of the next); then compound 2; then compound 3.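

The earlier compounds shown here suggested that an aryl group on this saturated ring carbon raises the number, but the 2-chlorophenyl of compound 4 shows no such penalty in this assay, with a 1.6-fold lower number from compound 1 to compound 4 (0.21 log units; within the scatter). What matters is therefore not the aryl ring alone but how it is substituted, as the move of the chloro group alone gives a 7.7-fold lower number from compound 2 to compound 4 (0.88 log units; beyond the scatter), and the change from the 3-(trifluoromethyl)phenyl gives a 21-fold lower number from compound 3 to compound 4 (1.32 log units; beyond the scatter). Nothing available here explains why the 2-chlorophenyl and 3-chlorophenyl groups differ so much.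

The compounds shown leave open whether a methoxy or methyl group on the same aryl ring would behave as the chloro group does. They also leave open how an amine, a carboxylic acid or a longer chain would fare on this saturated ring carbon.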